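The compounds below may be only part of what the source reports. "The series", "measured", "known", "first", "only" and "open" are said of these compounds alone.

Measured so far:
compound 1 `O=C1NC(c2ccccc2)CN1S(=O)(=O)c1ccc2c(c1)CCCN2` — 7230 nM
compound 2 `CC(C)COC(=O)N1CCCc2cc(S(=O)(=O)N3CC(c4ccccc4)NC3=O)ccc21` — 3720 nM

In a functional assay on COLO 205 cells (Homo sapiens) for antiproliferative activity, read by MTT assay (a higher number here means a weaker inhibitor, a lower number a stronger inhibitor), compound 2 gives 3720 nM and stands within the scatter of compound 1: a 1.9-fold lower number from compound 1 to compound 2 (0.29 log units; within the scatter). Compound 3 `O=C(CCl)NC(=O)N1CCCc2cc(S(=O)(=O)N3CC(c4ccccc4)NC3=O)ccc21` is the next step, with ((chloromethyl)carbonyl)amino in place of isobutoxy on a carbonyl carbon. Within the data shown here, no measured step touches this change; the single step known alters the substituent on the ring nitrogen rather than the group on the carbonyl carbon, and it was itself within the scatter. The number for compound 3 is therefore expected close to that of compound 2, with the expected step of a 1.2-fold lower number from compound 2 to compound 3 (0.09 log units; within the scatter). Compound 3 is estimated at 3000 nM, within 800 nM to 12000 nM.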

Compound 3, half-maximal inhibitory concentration: 9910 nM
Compound 3: the middle estimate sits 3.3-fold (0.52 log units) below what was measured, within the range that was stated.
By their numbers in this assay, from the lowest: compounds 2, 1 and 3 (each within the scatter of the next, the first and the last beyond it).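

In this assay, among these compounds, the change from isobutoxy to ((chloromethyl)carbonyl)amino on a carbonyl carbon gives a 2.7-fold higher number from compound 2 to compound 3 (0.43 log units; beyond the scatter) and is the first step beyond the scatter, so the group on this carbonyl carbon can shift the number. Measured against hydrogen on the ring nitrogen, the whole ((chloromethyl)carbonyl)carbamoyl group gives a 1.4-fold higher number from compound 1 to compound 3 (0.14 log units; within the scatter) and stays within the scatter, as isobutoxycarbonyl did. Nothing available accounts for the step. From the compounds shown here alone, whether an amine or a longer alkyl chain on this carbonyl carbon would give a number beyond the scatter of compound 2 stays open.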